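Thiophene in Place of Phenyl on the Sulfonyl Group

The compounds below may be only part of what the source reports. "The series", "measured", "known", "first", "only" and "open" are said of these compounds alone.

Compound 1 `CN(C)CCn1cc(S(=O)(=O)c2ccccc2)c2cccnc21` gives 25 nM in a functional assay on HeLa cells for agonist activity at 5-hydroxytryptamine receptor 6 (Homo sapiens), read by immunoassay; on this read-out higher numbers stand for an effect only at larger amounts of compound and lower numbers for an effect already at smaller amounts. Among the three measured compounds its number sits between those of the other two, yet both gaps are within the scatter: compound 3 `NCCn1cc(S(=O)(=O)c2cccc(F)c2)c2cccnc21` gives 24 nM, and compound 2 `Cc1c(S(=O)(=O)c2ccccc2)c2cccnc2n1CCN(C)C` gives 47 nM, the step of a 1.9-fold higher number from compound 1 to compound 2 (0.27 log units; within the scatter) belonging to a methyl added to the shared core. Compound 4 `CN(C)CCn1cc(S(=O)(=O)c2cccs2)c2cccnc21` differs from compound 1 by thiophen-2-yl in place of phenyl on a sulfonyl sulfur. For the measured compounds named here, no measured step touches the group on the sulfonyl sulfur, and compound 3 differs from compound 1 in two places, so nothing among the known numbers speaks for a move beyond the scatter. Compound 4 is therefore expected to give about 30 nM, estimated between 10 nM and 90 nM. The step of a 1.2-fold higher number from compound 1 to compound 4 (0.08 log units; within the scatter) is expected to stay within the scatter.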

Compound 4, half-maximal effective concentration: 154 nM
Compound 4: middle estimate off by 5.1-fold (0.71 log units), on the low side, outside the stated range (above it).
By their numbers in this assay, from the lowest: compounds 3, 1 and 2 (each within the scatter of the next); then compound 4.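

Swapping one aromatic ring for another on the sulfonyl sulfur is not a neutral change in this assay: thiophen-2-yl in place of phenyl gives (a 6.2-fold higher number from compound 1 to compound 4 (0.79 log units; beyond the scatter)) and is the only step shown that lies beyond the scatter. So this position responds to the identity of its ring, even though both rings are aromatic and uncharged. Nothing measured here explains why the number rises.

Still open, going by these compounds, is whether furan-2-yl or a pyridyl ring on the sulfonyl sulfur would behave like phenyl or like thiophen-2-yl. Also open, on these data alone, is whether the swap would have a similar effect in compound 2.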